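Varying the acrylamide tail on a shared quinazoline-free core

The compounds below may be only part of what the source reports. "The series", "measured", "known", "first", "only" and "open" are said of these compounds alone.

Of the compounds shown here, three share one core and have been tested in a functional assay on PC-3 cells (Homo sapiens) for antiproliferative activity, read by MTT assay, with a stated time of 72 h; on this read-out higher numbers stand for weaker inhibition and lower numbers for stronger inhibition. Compound 1 `C/C=C/C(=O)Nc1cc2c(N3CCc4ccccc43)ncnc2cc1OC` gives 8120 nM. Compound 2 `COc1cc2ncnc(N3CCCc4ccccc43)c2cc1NC(=O)C=C(C)C` gives 6130 nM, the lowest of the three numbers, though its gaps to the others lie within the scatter. Among the compounds with values here, compound 3 `CC(C)=CC(=O)Nc1cc2c(N3CCCc4ccccc43)ncnc2cc1O[C@@H]1CCOC1` gives 9020 nM; the one measured step, a 1.5-fold higher number from compound 2 to compound 3 (0.17 log units; within the scatter), changes only the ether substituent.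

Compound 4 `COc1cc2ncnc(N3CCCc4ccccc43)c2cc1NC(=O)/C=C/CN1CCC(CO)CC1` has not yet been measured. Compared with compound 2, the change is 3-(4-(hydroxymethyl)piperidin-1-yl)prop-1-en-1-yl in place of 2-methylprop-1-en-1-yl on a carbonyl carbon. Within the data shown here, no measured step touches the carbonyl-bearing tail, so nothing among the measured compounds bears directly on this change; the only step on record, between compound 2 and compound 3, concerns a different position and stays within the scatter. The expectation for compound 4 in this assay therefore rests on little, and is estimated as a modest downward move, a 2.0-fold lower number from compound 2 to compound 4 (0.31 log units; beyond the scatter), with a wide band. Compound 4 is expected to give about 3000 nM, between 700 nM and 13000 nM.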

Compound 4, half-maximal inhibitory concentration: 7150 nM
Compound 4: the middle estimate sits 2.4-fold (0.38 log units) below what was measured, and the stated range covers the measured number.
By their numbers in this assay, from the lowest: compounds 2, 4, 1 and 3 (each within the scatter of the next).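

In this assay, placing 3-(4-(hydroxymethyl)piperidin-1-yl)prop-1-en-1-yl instead of 2-methylprop-1-en-1-yl on the carbonyl carbon gives a 1.2-fold higher number from compound 2 to compound 4 (0.07 log units; within the scatter) for this change. Within the data shown here, this is the first measured step at this place, and it shows that the read-out does not separate the two groups, even though the entering one brings a six-membered non-aromatic ring and a hydrogen-bond donor. Nothing measured here offers an explanation for this result.

The compounds shown leave open whether the hydroxymethyl group matters, which a plain piperidine ring at the end of the same chain could test. They also leave open whether a dimethylamino group, a morpholine ring or a carboxylic acid in that place would give a number clearly apart from these.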